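This account rests on a few compounds, and the source may have more. Where it says the series, first, only, none or still open, it means among the compounds named here.

Measured in a functional assay on MCF7 cells (Homo sapiens) for inhibition, read by WST assay, with stated times of 72 h and 2 h; on this read-out lower numbers stand for stronger inhibition and higher numbers for weaker inhibition:
- Compound 1 `C#CCOC(c1cccs1)c1cc2ccccc2nc1Cl`: > 100000 nM, a limit and not a number
- Compound 2 `Clc1nc2ccccc2cc1C(OCc1ccccc1)c1cccs1`: 108000 nM

For the measured compounds named here, compound 2 gives 108000 nM, the only true number available in this assay. Nothing yet shows how this value compares with a more active compound of the series, although it lies at the high, weak end of the scale.

Compound 3 `FC(F)(F)c1cccc(COC(c2cccs2)c2cc3ccccc3nc2Cl)c1` keeps the structure of compound 2 but has trifluoromethyl in place of hydrogen on an aromatic carbon.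

Going by the values given here, the only measured step is a step that the limit leaves unreadable from compound 1 to compound 2. Its size stays hidden because of the limit of > 100000 nM in this assay, at which 1 of the 2 values shown sits. That step also changes a different place, so it offers no size to carry over to the new change. With no measured guide, a large step cannot be justified, and the expectation is a small one. Since compound 2 stands at 108000 nM, a slight move toward lower numbers is expected, possibly no more than the usual scatter.

The expected change is a 1.5-fold lower number from compound 2 to compound 3 (0.19 log units; within the scatter).

For compound 3 the estimated value is 70000 nM, with an expected range from 25000 nM to 150000 nM.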

Compound 3, half-maximal inhibitory concentration: 101000 nM
Beside the measured number, compound 3's estimate is 1.4-fold (0.16 log units) below it, and the stated range covers the measured number.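

Trifluoromethyl in place of hydrogen on an aromatic carbon, meta to a large group, gives a 1.1-fold lower number from compound 2 to compound 3 (0.03 log units; within the scatter) in this assay, the first step in this series that can be read as a number. Although four heavy atoms enter at this place, the values of compound 2 and compound 3 cannot be told apart, so this one swap at this one place gives no measurable gain or loss on this read-out. The step from compound 1 to compound 2 still cannot be read, because compound 1 carries a limit and not a number: the limit of > 100000 nM in this assay, at which 1 of the 3 values shown sits.

Going by these compounds, a single group at a single place says little about the six-membered aromatic ring as a whole, so it remains open whether an amine or a carboxylic acid at the same carbon would shift the number beyond the usual scatter. On these data alone, it is also open whether any change to the shared core or to the thiophene-free parts of the molecule would bring a value well down from the weak end of the scale.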